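A few compounds are considered here, and "the series" means these few. Any claim that something is new, unique, unknown or untested is made for them only; others in the source may bear on it.

Measured so far in a functional assay on PC-3 cells (Homo sapiens) for inhibition, read by MTT assay, with a stated time of 48 h; a higher number here means a weaker inhibitor, a lower number a stronger inhibitor:
compound 1 `C=C1CC[C@@H]2[C@](C)(CO)[C@H](O)CC[C@@]2(C)[C@@H]1CC(Sc1ccc(OC)cc1)C1=CCOC1=O`: 15000 nM
compound 2 `C=C1CC[C@@H]2[C@](C)(CO)[C@H](O)CC[C@@]2(C)[C@@H]1C/C=C1/C(=O)OC[C@H]1OC(=O)CSc1ccc([N+](=O)[O-])cc1`: 17000 nM

Of the two numbers, that of compound 2 is the larger, but its gap from compound 1 is within the scatter, so the two cannot be told apart in this assay. Compound 3 `C=C1CC[C@@H]2[C@](C)(CO)[C@H](O)CC[C@@]2(C)[C@@H]1C/C=C1/C(=O)OC[C@H]1OC(=O)CCCSc1ccccn1` differs from compound 2 in one place: 2-((pyridin-2-yl)sulfanyl)ethyl in place of (4-nitrophenyl)sulfanyl on a saturated chain carbon bound to a carbonyl carbon. Among the compounds with values here, no step between measured compounds is known here, so only the two values give a footing, and both sit at a similar level. Accordingly no step beyond the scatter is expected: a 1.1-fold lower number from compound 2 to compound 3 (0.05 log units; within the scatter). Compound 3 is estimated at 15000 nM, within a range from 5000 nM to 45000 nM.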

Compound 3, half-maximal inhibitory concentration: 14000 nM
For compound 3 the middle estimate is 1.1-fold (0.03 log units) above the measured one; measured number inside the range.
By their numbers in this assay, from the lowest: compounds 3, 1 and 2 (each within the scatter of the next).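

In this assay, putting 2-((pyridin-2-yl)sulfanyl)ethyl in place of (4-nitrophenyl)sulfanyl on a saturated chain carbon bound to a carbonyl carbon gives a 1.2-fold lower number from compound 2 to compound 3 (0.08 log units; within the scatter), the first one-place comparison available. This exchange of the nitro-bearing carbon ring for a pyridine ring on a longer chain therefore leaves the two compounds indistinguishable in this test. No supporting measurement bears on this result. As far as these compounds go, whether an amine or a carboxylic acid at this place would give a step beyond the scatter remains open. So does the effect of the longer chain apart from the ring, since both parts differ at once.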